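A few compounds are considered here, and "the series" means these few. Any claim that something is new, unique, unknown or untested is made for them only; others in the source may bear on it.

Measured in a functional assay on SW-620 cells (Homo sapiens) for inhibition, read by MTT assay, with a stated time of 72 h (a higher number here means a weaker inhibitor, a lower number a stronger inhibitor), so far:
compound 1 `O=C1O/C(=C\Cn2ncc(=O)[nH]c2=O)C(OCc2ccccc2)=C1OCc1ccccc1` gives 36500 nM.
compound 2 `NC1(CCn2ncc(=O)[nH]c2=O)OC(=O)C(OCc2ccccc2)=C1OCc1ccccc1` gives only a limit of the assay, > 100000 nM.
compound 3 `O=C1O[C@H]([C@@H](O)Cn2ccc(NC(=O)c3ccccc3)nc2=O)C(OCc2ccccc2)=C1OCc1ccccc1` gives only a limit of the assay, > 100000 nM.

Compound 2 therefore stands at the upper edge of what this assay reports; its value is a limit and not a number, and the same holds for compound 3 (the limit of > 100000 nM in this assay, at which 2 of the 3 values shown sit). Only compound 1 returns a number, and that number is weak. Within the data shown here, no pair of measured compounds differs in one place, so no measured step size is available to lean on.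

Compound 4 `Nc1ccn(CCC2(N)OC(=O)C(OCc3ccccc3)=C2OCc2ccccc2)c(=O)n1` is the next one in line. It differs from compound 2 by a group of 8 heavy atoms (4 carbon, 3 nitrogen, 1 oxygen; one six-membered aromatic ring with 2 hetero atoms) in place of a group of 8 heavy atoms (3 carbon, 3 nitrogen, 2 oxygen; one six-membered aromatic ring with 3 hetero atoms), on a saturated chain carbon, two bonds along the chain from a saturated ring carbon. The benzyloxy-bearing core with its amino group and the chain carrying the heterocycle are unchanged.

Given that compound 2 sits at a limit, no step beyond the usual scatter is expected from compound 2 to compound 4; the step of a number no higher from compound 2 to compound 4 (the limit leaves the size open) is expected to be essentially flat. In this assay compound 4 is estimated at 100000 nM, with a range from 30000 nM to 300000 nM, and the most likely outcome is that compound 4 again returns only a limit rather than a number.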

Compound 4, half-maximal inhibitory concentration: > 100000 nM
Compound 4 ended at the assay's limit; the forecaster's own chance of this, stated with the estimate: 65%; the middle value sits exactly at the limit.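

In this assay, compound 2 and compound 4 both return a limit and not a number, so no step can be read between them: the limit of > 100000 nM in this assay, at which 3 of the 4 values shown sit.

The compounds shown leave open whether replacing the six-membered aromatic ring with 3 hetero atoms by the one with 2 hetero atoms changes inhibition in this assay at all.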